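The source may hold more compounds than are shown below. What is called first, only, known or untested is meant among the compounds shown, and "the series" means these compounds.

Working notes on the oxadiazolyl-azetidine amide series.

Compound 1 `O=C(C1CCC(F)(F)CC1)N1CC(c2nc(-c3cccc(F)c3)no2)C1` carries a 4,4-difluorocyclohexyl group on the amide carbonyl. In an assay on HEK293 cells for negative allosteric modulation of metabotropic glutamate receptor 5 (Homo sapiens), read by FLIPR (on this read-out lower numbers stand for stronger inhibition and higher numbers for weaker inhibition), compound 1 gives > 10000 nM, which is a limit of the assay and not a number. Compound 2 `CC1CCC(C(=O)N2CC(c3nc(-c4cccc(Cl)c4)no3)C2)CC1` likewise gives only a limit, > 10000 nM, in this assay. Within the data shown here, compound 3 `O=C(C1CCCO1)N1CC(c2nc(-c3cccc(Cl)c3)no2)C1` is the one member with a number: in this assay compound 3 gives 890 nM. Among the measured compounds shown here, the single measured step is an at least 11-fold lower number from compound 2 to compound 3 (1.05 log units; beyond the scatter), so exchanging the saturated carbocycle on the carbonyl for a small oxygen heterocycle moved the series off the limit. Note that (the limit of > 10000 nM in this assay, at which 2 of the 3 values shown sit), so the starting points of the series are known only as limits.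

Compound 4 `Cc1ccc(C(=O)N2CC(c3nc(-c4cccc(F)c4)no3)C2)cc1` differs from compound 1 by 4-methylphenyl in place of 4,4-difluorocyclohexyl on a carbonyl carbon. For the measured compounds named here, no measured step exchanges a saturated ring for an aromatic one at this position; the only step that bears on it, from compound 2 to compound 3, shows that the carbonyl substituent can shift the read-out by a large amount. Compound 1 stands at a limit, so the direction of the step is expected to be toward a lower number, on the order of an at least 4.0-fold lower number from compound 1 to compound 4 (0.60 log units; beyond the scatter). Compound 4 is therefore estimated to give 2500 nM in this assay, between 400 nM and 10000 nM, with a real chance that only a limit is reported.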

Compound 4, half-maximal inhibitory concentration: > 10000 nM
Compound 4 gave a limit, no number; the forecaster's own chance of this, stated with the estimate: 35%; middle value at least 4.0-fold (0.60 log units) away from the limit.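

Compound 1 and compound 4 both stand at a limit in this assay, so no step between them can be read: the limit of > 10000 nM in this assay, at which 3 of the 4 values shown sit.

The compounds shown leave open whether 4-methylphenyl in place of 4,4-difluorocyclohexyl on a carbonyl carbon changes the read-out at all, and in which direction.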